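The compounds below may be only part of what the source reports. "The series", "measured", "known", "first", "only" and "open" are said of these compounds alone.

Measured compounds in an ADME assay on HepG2 cells (Homo sapiens) for cytotoxicity, read by luminescence, CellTiter-Glo and ATP content, with a stated time of 72 h; on this read-out lower numbers stand for an effect already at smaller amounts and higher numbers for an effect only at larger amounts of compound:
- compound 1 `COc1cccc(CNCCCNc2ccnc3cc(Oc4ccccc4)ccc23)c1O`: 6800 nM
- compound 2 `COc1cccc(CNCCCNc2ccnc3cc(-c4ccc(C(C)(C)C)cc4)ccc23)c1O`: 690 nM
- compound 3 `COc1cccc(CNCCCNc2ccnc3cc(Oc4cccc(N(C)C)c4)ccc23)c1O`: 7300 nM

Compound 3 stands at the highest of the three numbers, though its gap to compound 1 lies within the scatter, while compound 2 sits well apart with a markedly lower number. Compound 4 `COc1cccc(CNCCCNc2ccnc3cc(-c4ccc(C(F)(F)F)cc4)ccc23)c1O` is not yet measured; it differs from compound 3 in one place (4-(trifluoromethyl)phenyl in place of 3-(dimethylamino)phenoxy on an aromatic carbon). The group that leaves has two hydrogen-bond acceptors; the group that enters has none, and a fluorine-bearing carbon takes the place of a nitrogen-bearing one.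

Two measured steps speak to this change. Exchanging a phenoxy for a directly bonded 4-(tert-butyl)phenyl gave a 9.9-fold lower number from compound 1 to compound 2 (0.99 log units; beyond the scatter); the reverse kind of move gave an 11-fold higher number from compound 2 to compound 3 (1.02 log units; beyond the scatter). A similar move, from an aryl ether to a directly bonded substituted phenyl, is expected here, so a step of a 7.3-fold lower number from compound 3 to compound 4 (0.86 log units; beyond the scatter) is estimated, toward lower numbers and beyond the scatter. Compound 4 is therefore expected to give 1000 nM, within 400 nM to 3000 nM.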

Compound 4, half-maximal effective concentration: 2210 nM
Compound 4: middle estimate off by 2.2-fold (0.34 log units), on the low side, and the stated range covers the measured number.
By their numbers in this assay, from the lowest: compound 2; then compound 4; then compounds 1 and 3 (each within the scatter of the next).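

In this assay, swapping an ether-linked ring on this aromatic carbon for a directly bonded 4-(trifluoromethyl)phenyl also lowers the number (a 3.1-fold lower number from compound 1 to compound 4 (0.49 log units; beyond the scatter)) and (a 3.3-fold lower number from compound 3 to compound 4 (0.52 log units; beyond the scatter)), so the lower numbers here do not belong to 4-(tert-butyl)phenyl alone. With the directly bonded ring held constant, the substituent on that ring also matters: trifluoromethyl in place of tert-butyl gives (a 3.2-fold higher number from compound 2 to compound 4 (0.51 log units; beyond the scatter)). No measurement here explains why either change shifts the number.

It remains open how much of the shift comes from the direct bond and how much from the substituent, since the ether-linked and directly bonded rings shown carry different groups. Also open, on these data alone, is what an unsubstituted directly bonded phenyl would give, or one bearing a carboxylic acid or a primary amine.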